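A New Aryl Group on an Amine Nitrogen in a Ring

The source may report more compounds than this note shows. Statements on the series, on what has been measured and on what is new or still open speak of the compounds shown alone.

Compound 2 `O=C(CN1CCN(c2ncccn2)CC1)Nc1nc2ccccc2[nH]1` stands at 81.8% in a functional assay, read by spectrophotometry, with a stated time of 30 min, tested at 200 ug/mL (a lower number here means a weaker effect, a higher number a stronger effect of the compound at the concentration tested), and compound 1 `O=C(CN1CCN(c2ccccn2)CC1)Nc1nc2ccccc2[nH]1` stands at 76.2%, the two within the scatter of each other, as the step of a number 5.6 percentage points higher from compound 1 to compound 2 (within the scatter) shows. Compound 3 `COc1ccc(N2CCN(CC(=O)Nc3nc4ccccc4[nH]3)CC2)cc1` carries 4-methoxyphenyl in place of pyrimidin-2-yl on an amine nitrogen in a ring. No measured step covers this change; the one step shown, pyrimidin-2-yl for pyridin-2-yl, stayed within the scatter, so compound 3 is expected to move little, a number 5.8 percentage points lower from compound 2 to compound 3 (within the scatter), with no direction beyond the scatter. Compound 3 is therefore estimated at 76%, between 60% and 90%.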

Compound 3, a percentage reported as activity, at one concentration (the size of the read-out at that concentration, not a potency): 63.7%
Compound 3: middle estimate off by 12.3 percentage points, on the high side; measured number inside the range.
By their numbers in this assay, from the lowest: compound 3; then compounds 1 and 2 (each within the scatter of the next).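

For the compounds shown here, replacing either ring that holds nitrogen with the carbon-only 4-methoxyphenyl is the first change on this amine nitrogen to move the read-out in this assay beyond the scatter, giving a number 18.1 percentage points lower from compound 2 to compound 3 (beyond the scatter) and a number 12.5 percentage points lower from compound 1 to compound 3 (beyond the scatter). The position is therefore not indifferent to its aryl group, although pyridin-2-yl and pyrimidin-2-yl remain within the scatter of each other. Nothing available explains this drop.

On these data alone, the change alters the ring atoms and adds methoxy together, so the share of each remains open. A plain phenyl group would separate the two.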